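The compounds below may be only part of what the source reports. "The series", "measured", "known", "first", "only" and "open" are said of these compounds alone.

Compound 1 `OB1OCc2ccc(-n3cc(Sc4cccc(Cl)c4)c4ccccc43)cc21`: > 10 ug/mL
Compound 2 `CCCNC(=O)c1cccn1-c1ccc2c(c1)B(O)OC2`: > 10 ug/mL
Compound 3 `Cc1ccccc1C(=O)c1ccn(-c2ccc3c(c2)B(O)OC3)c1`: > 10 ug/mL

These three compounds were tested in an ADME assay on L929 cells (Mus musculus) for cytotoxicity, read by resazurin assay, with a stated time of 72 h; on this read-out higher numbers stand for weaker inhibition and lower numbers for stronger inhibition. Each of the values is a limit of the assay and not a number. For compound 1 the result is the limit > 10 ug/mL. For compound 2 the result is likewise the limit > 10 ug/mL. For compound 3 the result is the limit > 10 ug/mL. Compound 3 therefore stands where every compound shown stands, at the limit of > 10 ug/mL in this assay, at which 3 of the 3 values shown sit; no compound among the three is separated from another by a measured step, and nothing in this assay sets compound 3 apart.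

Compound 4 `O=C(c1ccn(-c2ccc3c(c2)B(O)OC3)c1)c1cccs1` has not yet been measured in this assay. It differs from compound 3 in one place: thiophen-2-yl in place of 2-methylphenyl on a carbonyl carbon. The change is small, and compound 3 sits at a limit shared by compound 1 and compound 2. In this assay compound 4 is expected to give 25 ug/mL, with a range from 8 ug/mL to 80 ug/mL. The expected step that the limit leaves unreadable from compound 3 to compound 4 is estimated to be none beyond the usual scatter, with the result most likely reported again as a limit.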

Compound 4, half-maximal inhibitory concentration: > 10 ug/mL
Compound 4: a limit, no number; the forecaster's own chance of this, stated with the estimate: 85%; the middle value lies beyond the limit too.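

Compound 3 and compound 4 both give a limit and not a number, so no step can be read from one to the other for thiophen-2-yl in place of 2-methylphenyl: the limit of > 10 ug/mL in this assay, at which 4 of the 4 values shown sit. The compounds shown leave open whether any of them differ at all in this assay.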